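A few compounds are considered here, and "the series" means these few. Any claim that something is new, unique, unknown or untested is made for them only; others in the source may bear on it.

Measured in an ADME assay on Vero cells (Chlorocebus sabaeus) for cytotoxicity, read by MTT assay, with a stated time of 72 h; a lower number here means that less compound is tolerated, a higher number that more compound is tolerated:
compound 1 `COC(=O)c1cc(-c2cccc(NC(=O)c3ccc(OCc4ccc(Cl)cc4)cc3)c2)on1` gives > 80 ug/mL, a limit of the assay.
compound 2 `COC(=O)c1cc(-c2cccc(NC(=O)c3ccc(/C=C/C(=O)c4ccc(C)cc4)cc3)c2)on1` gives > 80 ug/mL, also a limit of the assay.

Compound 2 therefore stands only at a limit in this assay, with no number of its own. Going by the values given here, the one measured step, a step that the two limits leave unreadable from compound 1 to compound 2, cannot be read, as both values sit at the limit of > 80 ug/mL in this assay, at which 2 of the 2 values shown sit. Compound 3 `COC(=O)c1cc(-c2cccc(NC(=O)c3ccc(/C=C/C(=O)c4ccc(OC)c(OC)c4)cc3)c2)on1` differs from compound 2 by 3,4-dimethoxyphenyl in place of 4-methylphenyl on a carbonyl carbon. Among the compounds with values here, no measured step bears on this change, so the step of a number no higher from compound 2 to compound 3 (the limit leaves the size open) is expected to be none beyond the scatter. Compound 3 is estimated at 80 ug/mL, range 40 ug/mL to 160 ug/mL, most likely again reported as a limit.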

Compound 3, half-maximal cytotoxic concentration: > 50 ug/mL
Compound 3 was reported as a limit; the forecaster's own chance of this, stated with the estimate: 75%; the middle value is on the limit's open side.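

In this assay compound 2 gives > 80 ug/mL, a limit. Going by these compounds alone, compound 3 gives > 50 ug/mL, also a limit, so no step from compound 2 can be read. Going by these compounds, whether 3,4-dimethoxyphenyl in place of 4-methylphenyl shifts tolerance at all stays open.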